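The source may hold more compounds than are shown below. What is called first, only, known or untested is meant among the compounds shown, and "the series" means these compounds.

Going by the values given here, in an ADME assay on a cell-free system (plasma, Homo sapiens) for metabolic stability, read by LC-MS (on this read-out higher numbers stand for a longer-lived compound and lower numbers for a shorter-lived compound), compound 2 (`NCc1ccc(C(=O)Nc2ccncc2F)cc1-c1cccc(C(=O)OCCO)c1`) gives 1.35 h, the higher of the two numbers so far, and compound 1 (`NCc1ccc(C(=O)Nc2ccncc2F)cc1-c1cccc(C(=O)Oc2ccccc2)c1`) gives 0.117 h. Compound 3 (`NCc1ccc(C(=O)Nc2ccncc2F)cc1-c1cccc(C(=O)OCC2CCCCO2)c1`) differs from compound 2 in one place: oxan-2-yl in place of hydroxymethyl on a saturated chain carbon bound to an oxygen next to a carbonyl group. Among the compounds with values here, only one measured step bears on this, a 12-fold higher number from compound 1 to compound 2 (1.06 log units; beyond the scatter). It was large, but it removed phenyl, whereas 2-hydroxyethyl to (oxan-2-yl)methyl leaves a saturated chain on that oxygen. No change beyond the scatter is therefore expected, and the estimated step is a 1.4-fold lower number from compound 2 to compound 3 (0.13 log units; within the scatter). Compound 3 is estimated at 1 h, with an expected range of 0.35 h to 3 h.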

Compound 3, half-life: 0.117 h
Compound 3: the middle estimate sits 8.5-fold (0.93 log units) above what was measured, outside the stated range (below it).
By their numbers in this assay, from the lowest: compounds 1 and 3 (each within the scatter of the next); then compound 2.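

In this assay, a saturated chain on this oxygen does not by itself hold the number up: oxan-2-yl in place of hydroxymethyl gives a 12-fold lower number from compound 2 to compound 3 (1.06 log units; beyond the scatter) and (oxan-2-yl)methyl in place of phenyl gives no change at the digits printed from compound 1 to compound 3 (within the scatter) here. Of the three compounds, only compound 2, with its hydroxymethyl end, stands apart. Nothing measured here explains that gap.

On these data alone, whether the hydroxymethyl end itself matters stays open. A 2-methoxyethyl group, a 2-aminoethyl group or a longer chain ending in hydroxymethyl could each be compared with compound 2 in one place.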